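The compounds below may be only part of what the source reports. "The series", "measured", "known", "first", "only" and "open" are said of these compounds alone.

Working notes on the series, read in an ADME assay (liver) for metabolic stability, with Liver microsome (Rattus norvegicus) as the target, read by LC-MS, using microsomes, with a stated time of 30 min, tested at 4 uM; on this read-out higher numbers stand for a more stable compound and lower numbers for a less stable compound. Compound 1 (`Cc1nc(N2CCN(C)CC2)c2nc(-c3ccccc3Cl)n(CCO)c2n1`) gives 6%; compound 2 (`Cc1nc(N2CCN(C)CC2)c2nc(-c3ccccc3Cl)n(CCN3CCCC3=O)c2n1`) gives 28%; compound 3 (`Cc1nc(N2CCN(C)CC2)c2nc(-c3ccccc3C(F)(F)F)n(C3CCOCC3)c2n1`) gives 38%. Compound 3 thus stands within the scatter of compound 2 and clearly beyond the scatter of compound 1, on the upper side.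

Compound 4 (`CCc1ccccc1-c1nc2c(N3CCN(C)CC3)nc(C)nc2n1C1CCOCC1`) departs from compound 3 at one place: ethyl in place of trifluoromethyl on an aromatic carbon. Seen one bond further out, 2-(trifluoromethyl)phenyl becomes 2-ethylphenyl.

Within the data shown here, only one measured step is available (a number 22 percentage points higher from compound 1 to compound 2 (beyond the scatter)). It is modest, though beyond the scatter, and it concerns 2-oxopyrrolidin-1-yl in place of hydroxy on a saturated chain, not the aromatic carbon changed here. It therefore bears on this change only as a rough gauge of how large a single swap can be in this series. Among the measured compounds shown here, no measured pair compares trifluoromethyl with ethyl, so the data fix no direction.

A step no larger than modest is expected, most likely within the scatter, with a slight downward lean that is judgement only. The expected step is a number 8 percentage points lower from compound 3 to compound 4 (within the scatter). The estimate for compound 4 is 30% (expected range 14% to 46%).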

Compound 4, percent of the compound remaining: 51%
For compound 4 the middle estimate is 21 percentage points below the measured one; measured number outside the range, above it.
By their numbers in this assay, from the lowest: compound 1; then compounds 2 and 3 (each within the scatter of the next); then compound 4.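

In this assay, ethyl in place of trifluoromethyl on an aromatic carbon, ortho to a large group, gives a number 13 percentage points higher from compound 3 to compound 4 (beyond the scatter). This is the first measured pair that changes only this place, so the read-out is now shown to respond to the group held there, and for this one swap the direction is upward, with the remainder of compound 3 left as it stands. Nothing measured in this series gives a reason for the step, which stands here as an observation on a single pair and says nothing yet about which feature of either group matters.

Open, as far as these compounds go, is whether the same swap would move the number in the same direction and by a similar amount on compounds carrying a different chain on the ring nitrogen, such as the 2-oxopyrrolidin-1-yl chain of compound 2. Also open, from the compounds shown here alone, is how other groups at this aromatic carbon would read against ethyl, for example methyl, a longer chain such as propyl, or methoxy, and so whether ethyl is a peculiar case or part of a wider trend.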